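Notes on a fluoro change to compound 1

The source may report more compounds than this note shows. Statements on the series, on what has been measured and on what is new or still open speak of the compounds shown alone.

- compound 1 `C=CCCCCOc1ccccc1-c1cnc(OCCC=C)n1C` gives 29000 nM
- compound 2 `C=CCCCCOc1ccc(OC)cc1-c1cnc(OCCC=C)n1C` gives 74000 nM
- compound 3 `C=CCCCCOc1ccc(F)cc1-c1cnc(OCCC=C)n1C` gives 87000 nM

Compound 1 has the lowest of the three numbers in a functional assay on T98G cells (Homo sapiens) for inhibition, read by colorimetric assay and MTT assay, with a stated time of 72 h (a higher number here means a weaker inhibitor, a lower number a stronger inhibitor), and is the strongest inhibitor measured so far, with its steps to both others beyond the scatter. Compound 4 `C=CCCCCOc1cc(F)ccc1-c1cnc(OCCC=C)n1C` is still unmeasured. It differs from compound 1 by fluoro in place of hydrogen on an aromatic carbon, a fluoro in place of hydrogen on an aromatic carbon, meta to a (hex-5-en-1-yl)oxy group and para to a large group.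

Among the compounds with values here, two measured steps bear most directly on this change. Fluoro in compound 3 gave a 3.0-fold higher number from compound 1 to compound 3 (0.48 log units; beyond the scatter) and methoxy in compound 2 gave a 2.6-fold higher number from compound 1 to compound 2 (0.41 log units; beyond the scatter), both modest and both toward weaker inhibition. The remaining step, a 1.2-fold higher number from compound 2 to compound 3 (0.07 log units; within the scatter), lies within the scatter, so these two substituted compounds cannot be ordered. Within the data shown here, compound 3 carries its fluoro at a different place on the ring, and no measured compound has a substituent at the place it occupies in compound 4, so the transfer is uncertain.

A modest rise is expected, and the estimated step is a 2.1-fold higher number from compound 1 to compound 4 (0.32 log units; beyond the scatter) in this assay on this reading. For compound 4 the estimated value is 60000 nM with an expected range from 25000 nM to 130000 nM in the same read-out.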

Compound 4, half-maximal inhibitory concentration: > 100000 nM
Compound 4 ended at the assay's limit; the forecaster's own chance of this, stated with the estimate: 10%; at least 1.6-fold (0.22 log units) between middle value and limit.
By their numbers in this assay, from the lowest: compound 1; then compounds 2 and 3 (each within the scatter of the next). At a limit, above all of these: compound 4.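

In this assay compound 4 gives > 100000 nM, which is a limit of the assay and not a number. Fluoro in place of hydrogen on this aromatic carbon, meta to a (hex-5-en-1-yl)oxy group and para to a large group, gives an at least 3.4-fold higher number from compound 1 to compound 4 (0.53 log units; beyond the scatter), so the first substituent seen at this place moves the number in the same direction as the substituents of compound 2 and compound 3. Compound 1 therefore remains the strongest inhibitor of the four, no compound shown goes against that direction, and the true size of the step at this place stays unresolved: the limit of > 100000 nM in this assay, at which 1 of the 4 values shown sits.

Whether the weaker inhibition at this carbon is particular to fluoro stays open, since the compounds shown carry no other group there, such as chloro, methyl, methoxy or an amine. Also open, as far as these compounds go, is whether any ring substituent, for example a carboxylic acid, or a longer chain in place of the (hex-5-en-1-yl)oxy group, could give a lower number than compound 1.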